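The source may report more compounds than this note shows. Statements on the series, on what has been measured and on what is new or still open speak of the compounds shown alone.

Measured so far in an assay on CHO cells for displacement of a labelled ligand from prostaglandin E2 receptor EP3 subtype (Mus musculus), read by scintillation counting; a lower number here means a stronger inhibitor, a higher number a weaker inhibitor:
- compound 1 `O=C(O)/C=C/c1ccc(Cn2ccnc2)cc1OCCCOc1ccccc1`: 280 nM
- compound 2 `O=C(O)/C=C/c1ccc(Cn2ccnc2)cc1OCCCCOc1ccccc1`: 220 nM

Compound 2 gives the lowest of the two numbers, though its step of a 1.3-fold lower number from compound 1 to compound 2 (0.10 log units; within the scatter) lies within the scatter, so the two compounds cannot be ranked. Compound 3 `O=C(O)/C=C/c1ccc(Cn2ccnc2)cc1OCCc1ccc2ccccc2c1` carries naphthalen-2-yl in place of 2-phenoxyethyl on a saturated chain carbon, two bonds along the chain from an oxygen on an aromatic ring. For the measured compounds named here, the only measured step, from compound 1 to compound 2, lengthened the chain by one carbon and changed little; it says nothing about losing the ether oxygen or placing two fused rings directly on the chain. Going by the values given here, with no closer precedent, the estimate for compound 3 is 300 nM (range 80 nM to 1200 nM), a step of a 1.4-fold higher number from compound 2 to compound 3 (0.13 log units; within the scatter) expected to remain within the scatter.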

Compound 3, inhibition constant: 16 nM
Compound 3: the middle estimate sits 19-fold (1.27 log units) above what was measured, and the stated range ends above it.
By their numbers in this assay, from the lowest: compound 3; then compounds 2 and 1 (each within the scatter of the next).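

Putting naphthalen-2-yl in place of 2-phenoxyethyl on this saturated chain carbon gives a 14-fold lower number from compound 2 to compound 3 (1.14 log units; beyond the scatter) in this assay, and putting it in place of phenoxymethyl gives an 18-fold lower number from compound 1 to compound 3 (1.24 log units; beyond the scatter). For the compounds shown here, this position therefore responds strongly to the group it carries, whereas the one earlier step, a single added chain carbon, stayed within the scatter.

Still open, on these data alone, is whether the difference follows the lost ether oxygen or the second fused ring, and whether a plain phenyl or a quinolinyl group on the same chain would match it. No measurement at hand explains the result.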